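A single ring change at the low end

The source may report more compounds than this note shows. Statements on the series, on what has been measured and on what is new or still open speak of the compounds shown alone.

Measured in a physicochemical assay for solubility, read by spectrophotometry, in phosphate buffer, with a stated time of 18 h, at pH 7.4; a higher number here means a more soluble compound, a lower number a less soluble compound:
- Compound 1 `CCc1ccc(-c2nc3c(c(C)nn3-c3ccccc3)c(-c3ccccc3I)c2C#N)cc1`: 8500 nM
- Compound 2 `CCc1ccc(-c2nc3c(c(C)nn3-c3ccccc3)c(-c3ccc(O)cc3)c2C#N)cc1`: 5700 nM
- Compound 3 `Cc1nn(-c2ccccc2)c2nc(-c3ccc4ccccc4c3)c(C#N)c(-c3ccccc3O)c12`: 1800 nM

Compound 3 has the lowest number of the three, and its gaps to compound 1 and compound 2 lie beyond the scatter. Compound 4 `Cc1nn(-c2ccccc2)c2nc(-c3ccc4c(c3)CCCC4)c(C#N)c(-c3ccccc3O)c12` differs from compound 3 in one group: 1,2,3,4-tetrahydronaphthalen-6-yl in place of naphthalen-2-yl on an aromatic carbon. The group sits next to the ring nitrogen and ortho to a cyano group.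

Among the compounds with values here, only one measured step changes a single place, a 1.5-fold lower number from compound 1 to compound 2 (0.17 log units; within the scatter), and it stays within the scatter. That step exchanges 2-iodophenyl for 4-hydroxyphenyl, so no measurement tests the naphthalen-2-yl group itself, and the guide is weak. In this assay the expected step is a 1.1-fold higher number from compound 3 to compound 4 (0.05 log units; within the scatter), nothing beyond the scatter. Compound 4 is estimated at 2000 nM, with an expected range of 900 nM to 4500 nM.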

Compound 4, solubility: 13000 nM
Estimate against measurement, compound 4: 6.5-fold (0.81 log units) below; the measured number lies above the stated range.
By their numbers in this assay, from the lowest: compound 3; then compounds 2, 1 and 4 (each within the scatter of the next, the first and the last beyond it).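

At this position on the shared core, exchanging one aromatic ring for a non-aromatic ring, with 10 heavy atoms on both sides and no hydrogen-bond donors or acceptors in either group, gives in this assay a 7.2-fold higher number from compound 3 to compound 4 (0.86 log units; beyond the scatter). Within the data shown here, this is the first single-place step here to lie beyond the scatter, so the group at this position can matter in this assay. Nothing measured here accounts for the size of this step.

Going by these compounds, it remains open how an amine or a carboxylic acid on the non-aromatic ring would read. On these data alone, it is also open whether the same exchange gives a similar step when the 2-hydroxyphenyl group is replaced.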